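The source may hold more compounds than are shown below. What is called first, only, known or untested is meant among the compounds shown, and "the series" means these compounds.

Three measured compounds share one core and differ in a single group. In a functional assay on KB cells (Homo sapiens) for antiproliferative activity (on this read-out lower numbers stand for stronger inhibition and higher numbers for weaker inhibition), compound 1 `COc1ccc(S(=O)(=O)N2CCc3cccc(Nc4ccc(O)cc4)c32)cc1` with hydroxy gives 239 nM and compound 2 `COc1ccc(S(=O)(=O)N2CCc3cccc(Nc4ccccc4)c32)cc1` with hydrogen in that place gives 342 nM in the same read-out, a pair within the scatter of each other. Compound 3 `COc1ccc(S(=O)(=O)N2CCc3cccc(Nc4ccc(Cl)cc4)c32)cc1` with chloro gives 1100 nM as the highest number of the three, the weakest inhibition among them. Compound 4 `COc1ccc(S(=O)(=O)N2CCc3cccc(Nc4ccc(F)cc4)c32)cc1` is still unmeasured and departs from compound 3 by one exchange fluoro in place of chloro on an aromatic carbon on an aromatic carbon para to a large group, fluoro in place of chloro. Within the data shown here, no fluoro compound has been measured, so only the neighbouring steps can guide. Chloro in place of hydrogen gives a 3.2-fold higher number from compound 2 to compound 3 (0.51 log units; beyond the scatter) and chloro in place of hydroxy gives a 4.6-fold higher number from compound 1 to compound 3 (0.66 log units; beyond the scatter) while hydrogen in place of hydroxy gives a 1.4-fold higher number from compound 1 to compound 2 (0.16 log units; within the scatter) and stays within the scatter. Assuming that fluoro sits closer to hydrogen than chloro does here, a modest lower number is expected in this assay that takes back part of the step from hydrogen to chloro. The estimate is thus a 2.1-fold lower number from compound 3 to compound 4 (0.33 log units; beyond the scatter) for this exchange. The expected value for compound 4 is 520 nM within an estimated range of 230 nM to 1150 nM on this reasoning.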

Compound 4, half-maximal inhibitory concentration: 557 nM
The estimate for compound 4 lay 1.1-fold (0.03 log units) below the measured number, within the range that was stated.
By their numbers in this assay, from the lowest: compounds 1, 2, 4 and 3 (each within the scatter of the next, the first and the last beyond it).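

In this assay, the exchange of chloro for fluoro gives a 2.0-fold lower number from compound 3 to compound 4 (0.30 log units; within the scatter) and so does not separate the two halogens at this position, although chloro stood clear of both hydrogen and hydroxy. Fluoro likewise cannot be told apart from hydrogen, with a 1.6-fold higher number from compound 2 to compound 4 (0.21 log units; within the scatter) as the step, while hydroxy in place of fluoro is the one comparison that clears the scatter, read as a 2.3-fold higher number from compound 1 to compound 4 (0.37 log units; beyond the scatter) in the listed direction. Fluoro thus lies within the scatter of both hydrogen and chloro, even though those two differ beyond it.

Nothing shown gives a reason for these numbers. Going by these compounds, whether an amine or a nitrile at this position would stand with hydroxy or with chloro remains open, as does whether these steps hold on any other read-out.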